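Working notes: chloro on compound 3

The source may report more compounds than this note shows. Statements on the series, on what has been measured and on what is new or still open speak of the compounds shown alone.

Values in a functional assay on HepG2 cells (Homo sapiens) for cytotoxicity, read by CCK-8 assay; a higher number here means a weaker inhibitor, a lower number a stronger inhibitor:
- Compound 1 `Cc1ccc(NC(=O)c2ncc(-c3ccccc3)o2)cc1`: > 30000 nM, a limit
- Compound 2 `CCN(CC)c1ccc(NC(=O)c2ncc(-c3ccccc3)o2)cc1`: > 30000 nM, a limit
- Compound 3 `O=C(c1ncc(-c2ccccc2)o1)N1CCN(c2ccccc2)CC1`: > 30000 nM, a limit

Compound 3 has no number, only its limit. The series offers no number either: the limit of > 30000 nM in this assay, at which 3 of the 3 values shown sit. Compound 4 `O=C(c1ncc(-c2ccccc2)o1)N1CCN(c2ccc(Cl)cc2)CC1` differs by chloro in place of hydrogen on an aromatic carbon, para to a large group: chloro in place of hydrogen on an aromatic carbon. Within the data shown here, the one measured step, a step that the two limits leave unreadable from compound 1 to compound 2, lies at another place and gives no size to carry over. No step beyond the scatter is therefore expected in this assay, and no direction can be given. The expected outcome is a number no higher from compound 3 to compound 4 (the limit leaves the size open). For compound 4 the estimated value is 30000 nM, with an expected range from 15000 nM to 60000 nM.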

Compound 4, half-maximal inhibitory concentration: > 30000 nM
Compound 4 was reported as a limit (the forecaster's own chance of this, stated with the estimate: 85%); the middle value sits exactly at the limit.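

No step can be read between compound 3 and compound 4, because both values are limits and not numbers: the limit of > 30000 nM in this assay, at which 4 of the 4 values shown sit.

The compounds shown leave open whether chloro in place of hydrogen changes the read-out at all in this assay.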